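The compounds below may be only part of what the source reports. "The series", "measured", "known", "first", "only" and "open" are said of these compounds alone.

In a functional assay on OVCAR-3 cells (Homo sapiens) for antiproliferative activity, read by MTT assay, with a stated time of 24 h (a lower number here means a stronger inhibitor, a higher number a weaker inhibitor), two compounds sharing a core have been measured so far. Compound 1 `O=C(NNc1ccc(F)cc1)c1ccc(NS(=O)(=O)c2cnc(O)nc2O)cc1` gives > 20000 nM, which is a limit of the assay and not a number. Among the measured compounds shown here, compound 2 `O=C(NNC(=O)c1ccccc1F)c1ccc(NS(=O)(=O)c2cnc(O)nc2O)cc1` gives 16000 nM, the only actual number available, so it has no measured neighbour to be ranked against. For the measured compounds named here, the one measured step, an at least 1.2-fold lower number from compound 1 to compound 2 (0.09 log units; that floor lies within the scatter), does not go beyond the scatter.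

Compound 3 `O=C(NNC(=O)c1ccc(NS(=O)(=O)c2cnc(O)nc2O)cc1)c1ccc(F)cc1` has the same atoms as compound 2, joined differently: 4-fluorophenyl in place of 2-fluorophenyl on a carbonyl carbon. In words, 4-fluorophenyl stands in place of 2-fluorophenyl on a carbonyl carbon whose other neighbour is an amide-type nitrogen.

No measurement tests this change directly. The nearest evidence is an at least 1.2-fold lower number from compound 1 to compound 2 (0.09 log units; that floor lies within the scatter), which also involves these fluorophenyl groups but shows no effect larger than the scatter. With so little to go on, compound 2 at 16000 nM remains the anchor, and no shift in either direction can be argued. The expected size of the change in this assay, no change at the digits printed from compound 2 to compound 3 (within the scatter), is therefore none beyond the scatter. Compound 3 is estimated at 16000 nM, with an expected range of 7000 nM to 32000 nM.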

Compound 3, half-maximal inhibitory concentration: > 20000 nM
Compound 3: no number, only a limit; the forecaster's own chance of this, stated with the estimate: 35%; middle value at least 1.2-fold (0.09 log units) from the limit.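

In this assay compound 3 gives > 20000 nM, which is a limit of the assay and not a number. Among the compounds shown here, this is the first direct test of 4-fluorophenyl in place of 2-fluorophenyl on a carbonyl carbon whose other neighbour is an amide-type nitrogen, and it gives an at least 1.2-fold higher number from compound 2 to compound 3 (0.09 log units; that floor lies within the scatter), so what can be read of this change does not go beyond the scatter, and its true size remains unknown. The step from compound 1 to compound 3 cannot be read, and one feature of the data bounds what this set can show: the limit of > 20000 nM in this assay, at which 2 of the 3 values shown sit.

Compound 2 gives 16000 nM. What the compounds shown leave open is whether any group on this carbonyl carbon moves the number of compound 2 beyond the scatter. Plain phenyl, 4-chlorophenyl or 4-aminophenyl in the same place would show whether the fluorine or its place on the ring matters at all in this assay, or whether the shared core alone sets these values.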